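Swapping the aryl amide substituent in a dopamine receptor agonist series

A few compounds are considered here, and "the series" means these few. Any claim that something is new, unique, unknown or untested is made for them only; others in the source may bear on it.

Of the compounds shown here, three have been tested in a functional assay on HEK293 cells for agonist activity at D(4) dopamine receptor (Homo sapiens), read by FLIPR; on this read-out higher numbers stand for an effect only at larger amounts of compound and lower numbers for an effect already at smaller amounts. Compound 1 `O=C(CN1CCC(c2cccc[n+]2[O-])CC1)Nc1cc(Cl)cc(Cl)c1` gives 160 nM, the second highest of the three numbers. Compound 2 `O=C(NCN1CCC(c2cccc[n+]2[O-])CC1)c1ccc2ccccc2c1` gives 115 nM, which lies within the usual scatter of the value of compound 1. Compound 3 `Cc1cccc(NC(=O)CN2CCC(c3ccccc3C)CC2)c1` gives 340 nM, a number beyond the scatter above that of compound 1.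

Compound 4 `Cc1cccc(C)c1NC(=O)CN1CCC(c2cccc[n+]2[O-])CC1` has not yet been measured. It differs from compound 1 in one place: 2,6-dimethylphenyl in place of 3,5-dichlorophenyl on an amide-type nitrogen. Going by the values given here, no measured pair shows this exact exchange, so the direction of the step is open. Among the compounds with values here, a modest rise in the number is expected, because compound 3, the only other compound carrying a methyl-bearing aryl group, gives 340 nM. The step from compound 1 to compound 4 is thus expected to be a 1.9-fold higher number from compound 1 to compound 4 (0.27 log units; within the scatter). Compound 4 is estimated at 300 nM, with a range from 100 nM to 900 nM.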

Compound 4, half-maximal effective concentration: 346 nM
The estimate for compound 4 lay 1.2-fold (0.06 log units) below the measured number; the measured number falls inside the stated range.
By their numbers in this assay, from the lowest: compounds 2 and 1 (each within the scatter of the next); then compounds 3 and 4 (each within the scatter of the next).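

In this assay the exchange of 3,5-dichlorophenyl for 2,6-dimethylphenyl on the amide-type nitrogen gives a 2.2-fold higher number from compound 1 to compound 4 (0.33 log units; beyond the scatter) and so shows that this position responds to the aryl group, if only modestly. The two groups have the same number of heavy atoms and the same type of ring, so this count alone does not settle the number. Nothing measured here gives a reason for the step.
From the compounds shown here alone, it remains open whether the step follows from chlorine giving way to methyl or from where these groups sit on the ring. Going by these compounds, how an aryl group carrying an amine or a carboxylic acid would behave at this position also remains open.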